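The source may hold more compounds than are shown below. What is called first, only, known or untested is meant among the compounds shown, and "the series" means these compounds.

Measured so far in an assay on isolated protein for inhibition of hexokinase-2 (Rattus norvegicus), with a stated time of 6 h, tested at 10 mM; on this read-out lower numbers stand for less inhibition and higher numbers for more inhibition at the one concentration tested (going by the name of the read-out):
- compound 1 `O=C(CI)NCCCCCC(=O)NCCCCCCNc1ncnc2c1ncn2[C@@H]1O[C@H](COP(=O)(O)OP(=O)(O)OP(=O)(O)O)[C@@H](O)[C@H]1O` gives 0%
- compound 2 `Nc1ncnc2c1nc(NCCCCCCCCNC(=O)CI)n2[C@@H]1O[C@H](COP(=O)(O)OP(=O)(O)OP(=O)(O)O)[C@@H](O)[C@H]1O` gives 0%
- compound 3 `O=C(CI)NCCCCCCCCNc1ncnc2c1ncn2[C@@H]1O[C@H](COP(=O)(O)OP(=O)(O)OP(=O)(O)O)[C@@H](O)[C@H]1O` gives 41%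

Compound 2 stands level with compound 1 at the digits reported, the two together the lowest of the three numbers; the gap between them lies within the scatter, so no order is read between them. Compound 3 sits a number some way higher than compound 2, and that gap lies beyond the scatter. Going by the values given here, compound 3 differs from compound 2 in more than one place, so no single step is drawn between them.

The next compound, compound 4 `Nc1ncnc2c1nc(NCCCCNC(=O)CI)n2[C@@H]1O[C@H](COP(=O)(O)OP(=O)(O)OP(=O)(O)O)[C@@H](O)[C@H]1O`, is reached from compound 2 by one change: ((iodomethyl)carbonyl)amino in place of 4-(((iodomethyl)carbonyl)amino)butyl on a saturated chain carbon, four bonds along the chain from a nitrogen on an aromatic ring. Among the compounds with values here, no measured pair in this assay shows the effect of shortening this chain, so the size of the step is not anchored by data. Compound 2 gives 0% in this assay, and compound 1 stands level with it at the digits reported. With nothing pointing upward, the step from compound 2 to compound 4 is expected to be small, a number 5 percentage points higher from compound 2 to compound 4 (within the scatter). Compound 4 is therefore estimated to give 5% in this assay, with a range from 0% to 25%.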

Compound 4, a percentage reported as inhibition, at one concentration (the size of the read-out at that concentration, not a potency): 0%
Compound 4: the middle estimate sits 5 percentage points above what was measured, within the range that was stated.
By their numbers in this assay, from the lowest: compounds 1, 2 and 4 (each within the scatter of the next); then compound 3.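

In this assay, going by these compounds alone, putting ((iodomethyl)carbonyl)amino in place of 4-(((iodomethyl)carbonyl)amino)butyl on a saturated chain carbon, four bonds along the chain from a nitrogen on an aromatic ring, reads as no change at the digits printed from compound 2 to compound 4 (within the scatter), the first single-change step. Compound 2 gives 0% and compound 4 gives 0%, so neither chain length at this place lifts the read-out above that level, and any loss on shortening could not be seen there. Nothing available explains this flat result.

Still open, as far as these compounds go, is whether a longer chain at this place, or an amine or a carboxylic acid in place of the iodomethyl carbonyl end, would raise the number in this assay above the level of compound 4. Also open, from the compounds shown here alone, is whether the same shortening in the chain of compound 3, which gives 41%, would move that number, since the present step starts from a compound with no measurable inhibition.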